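Halogenated benzyl in place of 3-methylbenzyl on the ring nitrogen

The compounds below may be only part of what the source reports. "The series", "measured", "known", "first", "only" and "open" are said of these compounds alone.

compound 1, `CCCn1c(=O)[nH]c2nc(-c3ccc(S(=O)(=O)N4CCN(Cc5cccc(C)c5)CC4)cc3)[nH]c2c1=O`: in an assay on CHO cells for displacement of a labelled ligand from adenosine receptor A1 (Homo sapiens), read by scintillation counting, with a stated time of 90 min, in the presence of a further agent that is not named here (a lower number here means a stronger inhibitor, a higher number a weaker inhibitor), compound 1 gives 795 nM
compound 2, `CCCn1c(=O)[nH]c2nc(-c3ccc(S(=O)(=O)N4CCN(c5cccc(Cl)c5)CC4)cc3)[nH]c2c1=O`: compound 2 gives only the limit > 1000 nM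
compound 3, `CCCn1c(=O)[nH]c2nc(-c3ccc(S(=O)(=O)N4CCN(c5ccccc5Br)CC4)cc3)[nH]c2c1=O`: compound 3 gives only the limit > 1000 nM

Compound 1 is the only one of the three with a number; the others sit at the limit of > 1000 nM in this assay, at which 2 of the 3 values shown sit. The steps of an at least 1.2-fold higher number from compound 1 to compound 2 (0.09 log units; that floor lies within the scatter) and an at least 1.2-fold higher number from compound 1 to compound 3 (0.09 log units; that floor lies within the scatter) are therefore floors only, and a step that the two limits leave unreadable from compound 2 to compound 3 cannot be read. Compound 4, `CCCn1c(=O)[nH]c2nc(-c3ccc(S(=O)(=O)N4CCN(Cc5ccc(Br)c(F)c5)CC4)cc3)[nH]c2c1=O`, differs from compound 1 by 4-bromo-3-fluorophenyl in place of 3-methylphenyl on a saturated chain carbon bound to an amine nitrogen in a ring. Unlike compounds 2 and 3, it keeps the saturated chain carbon between the aromatic ring and the amine nitrogen in the ring, so the measured steps bear on it only loosely. No step beyond the scatter is expected from compound 1 to compound 4, a 1.1-fold higher number from compound 1 to compound 4 (0.05 log units; within the scatter). Compound 4 is estimated at 900 nM, between 350 nM and 2500 nM.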

Compound 4, inhibition constant: 326 nM
Compound 4: middle estimate off by 2.8-fold (0.44 log units), on the high side, outside the stated range (below it).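

On the saturated chain carbon, 4-bromo-3-fluorophenyl in place of 3-methylphenyl gives a readable step beyond the scatter, which the earlier floors did not: a 2.4-fold lower number from compound 1 to compound 4 (0.39 log units; beyond the scatter). Compound 4 also separates from the compounds without the chain carbon, with an at least 3.0-fold lower number from compound 3 to compound 4 (0.48 log units; beyond the scatter) and an at least 3.0-fold lower number from compound 2 to compound 4 (0.48 log units; beyond the scatter). These two steps are floors, since compounds 2 and 3 give limits and not numbers: the limit of > 1000 nM in this assay, at which 2 of the 4 values shown sit.

As far as these compounds go, whether the bromine or the fluorine alone would carry the step stays open. So does the outcome for a benzyl bearing an amine or a carboxylic acid at this position.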